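The compounds below may be only part of what the source reports. "The series", "measured", "known", "first", "only" and "open" are said of these compounds alone.

In a functional assay on BT-549 cells (Homo sapiens) for inhibition, read by sulforhodamine B assay, with a stated time of 48 h (a lower number here means a stronger inhibitor of growth, a higher number a weaker inhibitor of growth), three compounds have been measured:

Compound 1, `COc1cc(OC)cc(-c2ccc(-c3ccc(C(=N)N)c(F)c3)s2)c1`, gives 1370 nM.
Compound 2, `N=C(N)c1ccc(-c2ccc(-c3ccc(Cl)cc3)s2)cc1F`, gives 1500 nM.
Compound 3, `N=C(N)c1ccc(-c2ccc(-c3ccc(Cl)cc3)s2)cc1`, gives 1730 nM.

The three numbers lie close together, and none of the gaps between them is beyond the scatter of this assay. How the core of compound 1 differs from the core of compound 2 is not broken down here. Between compound 2 and compound 3 the single change is hydrogen in place of fluoro on an aromatic carbon, and it made a 1.2-fold higher number from compound 2 to compound 3 (0.06 log units; within the scatter).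

Compound 4, `COc1cc(OC)cc(-c2ccc(-c3ccc(C(=N)N)cc3)s2)c1`, has not yet been measured. It differs from compound 1 by hydrogen in place of fluoro on an aromatic carbon, the same change as that from compound 2 to compound 3. For compound 4 the expected step is therefore a 1.2-fold higher number from compound 1 to compound 4 (0.07 log units; within the scatter), resting on the step seen from compound 2 to compound 3, a 1.2-fold higher number from compound 2 to compound 3 (0.06 log units; within the scatter). Compound 4 is thus estimated to give 1600 nM, with a range from 800 nM to 3200 nM.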

Compound 4, concentration for 50% growth inhibition: 1800 nM
Estimate against measurement, compound 4: 1.1-fold (0.05 log units) below, within the range that was stated.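

In this assay, hydrogen in place of fluoro on the core of compound 1 gave a 1.3-fold higher number from compound 1 to compound 4 (0.12 log units; within the scatter). Set beside the earlier case, the change reads alike on the two cores: the same change on two cores in this assay, a 1.2-fold higher number (0.06 log units; within the scatter) from compound 2 to compound 3 and a 1.3-fold higher number (0.12 log units; within the scatter) from compound 1 to compound 4, 1.1-fold (0.06 log units) apart, within the scatter of two such steps

So, on these two cores, the change carried over without a discernible difference, but each step lies within the scatter, so neither shows that the fluoro matters for growth inhibition, and two cores do not establish a rule for the series.

The compounds shown leave open whether a nitrile or a trifluoromethyl group on that aromatic carbon would give a step beyond the scatter. They also leave open whether the fluoro change would read alike on a core carrying an amine in place of the chloro or methoxy groups.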